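Oxazolyl in place of chloropyridinyl: expected permeability drop

This account rests on a few compounds, and the source may have more. Where it says the series, first, only, none or still open, it means among the compounds named here.

Compound 1 `C[C@@H](Oc1cc2oc(=O)n(CCC(=O)O)c2cc1Cl)c1ccc(Cl)cn1`: 60 nm/s
Compound 2 `O=C(O)CCn1c(=O)oc2cc(OCC3CC3)c(Cl)cc21`: 19 nm/s
Compound 3 `C[C@@H](Oc1cc2oc(=O)n(CCC(=O)O)c2cc1Cl)c1ncccn1`: < 3 nm/s (a limit)

In a physicochemical assay for permeability, using PAMPA (a higher number here means that the compound crosses the layer faster, a lower number that the compound crosses the layer more slowly), compound 1 stands highest of the two numbers shown, with compound 2 the nearest. Compound 3 reaches only the limit (the limit of < 3 nm/s in this assay, at which 1 of the 3 values shown sits). The step from compound 1 to compound 3 is an at least 20-fold lower number from compound 1 to compound 3 (1.30 log units; beyond the scatter), and the step from compound 2 to compound 3 is an at least 6.3-fold lower number from compound 2 to compound 3 (0.80 log units; beyond the scatter). Compound 4 `C[C@@H](Oc1cc2oc(=O)n(CCC(=O)O)c2cc1Cl)c1ncco1` differs from compound 1 in one place: 1,3-oxazol-2-yl in place of 5-chloropyridin-2-yl on a saturated chain carbon bound to an oxygen on an aromatic ring and a saturated chain carbon. Since this also brings a six-membered two-heteroatom ring's cousin, a five-membered ring with two hetero atoms, onto the same carbon, a clear drop is expected, though perhaps smaller than for compound 3. Compound 4 is therefore expected to give 8 nm/s, between 3 nm/s and 25 nm/s, a step of a 7.5-fold lower number from compound 1 to compound 4 (0.88 log units; beyond the scatter).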

Compound 4, apparent permeability: < 3 nm/s
Compound 4 was reported as a limit (the forecaster's own chance of this, stated with the estimate: 30%); middle value at least 2.6-fold (0.42 log units) from the limit.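

Compound 4 gives < 3 nm/s in this assay, which is a limit and not a number. Replacing 5-chloropyridin-2-yl on this carbon with the five-membered 1,3-oxazol-2-yl gives an at least 20-fold lower number from compound 1 to compound 4 (1.30 log units; beyond the scatter), and the comparison with the smaller group on the oxygen gives an at least 6.3-fold lower number from compound 2 to compound 4 (0.80 log units; beyond the scatter). A five-membered ring and a six-membered ring on this carbon now both end at the same limit: the limit of < 3 nm/s in this assay, at which 2 of the 4 values shown sit.

The step between compound 3 and compound 4 cannot be read, as both are limits. As far as these compounds go, it remains open whether a phenyl or a 5-chloropyrimidin-2-yl group on this carbon would give a value above the limit.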